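Acylhydrazone series: aryl swap on the carbonyl carbon

The compounds below may be only part of what the source reports. "The series", "measured", "known", "first", "only" and "open" are said of these compounds alone.

Measured so far:
compound 1 `CC1=C/C(=N\NC(=O)c2ccncc2)c2c(O)cccc2C1=O`: 3300 nM
compound 2 `CC1=C/C(=N\NC(=O)c2cccnc2)c2c(O)cccc2C1=O`: 1900 nM

Both were tested in a functional assay on MDA-MB-468 cells (Homo sapiens) for antiproliferative activity, read by MTT assay, with a stated time of 48 h; a lower number here means a stronger inhibitor, a higher number a weaker inhibitor. On the numbers shown, compound 2 carries the smaller of the two, but the step of a 1.7-fold lower number from compound 1 to compound 2 (0.24 log units; within the scatter) lies within the scatter, so the two compounds cannot be separated on this assay and no rank between them is claimed.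

Compound 3 `CC1=C/C(=N\NC(=O)c2ccccc2O)c2c(O)cccc2C1=O` keeps the shared core and the acylhydrazone link of compound 2 and differs in one place: 2-hydroxyphenyl in place of pyridin-3-yl on a carbonyl carbon. Among the compounds with values here, no measured step touches this kind of change. Within the data shown here, the only step available, a 1.7-fold lower number from compound 1 to compound 2 (0.24 log units; within the scatter), exchanges one pyridinyl for another on the same carbonyl carbon and stays within the scatter; it says nothing about replacing a pyridinyl with a hydroxyphenyl. Among the measured compounds shown here, with the series so far giving two numbers close together, a move beyond the scatter in either direction in this assay is not expected, and compound 2 is taken as the anchor.

For compound 3 the expected value is 1900 nM, within an estimated range of 600 nM to 6000 nM. The step this estimate implies, no change at the digits printed from compound 2 to compound 3 (within the scatter), is expected to remain within the scatter.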

Compound 3, half-maximal inhibitory concentration: 2900 nM
Compound 3: the middle estimate sits 1.5-fold (0.18 log units) below what was measured; the measured number falls inside the stated range.
By their numbers in this assay, from the lowest: compounds 2, 3 and 1 (each within the scatter of the next).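

In this assay, putting 2-hydroxyphenyl on the carbonyl carbon in place of a pyridinyl gives a 1.5-fold higher number from compound 2 to compound 3 (0.18 log units; within the scatter) and a 1.1-fold lower number from compound 1 to compound 3 (0.06 log units; within the scatter) in the two comparisons available. The earlier pair exchanged only one pyridinyl for another, whereas these steps show that, among the three compounds, a ring of carbon only carrying a hydroxyl cannot be separated from either pyridinyl ring at this place, even though the ring nitrogen leaves and a hydrogen-bond donor enters. No accompanying measurement bears on this result, so the flat reading stays a plain observation on compounds 1, 2 and 3.

On these data alone, all three groups on the carbonyl carbon are six-membered aromatic rings, so it remains open whether a plain phenyl ring, a saturated ring such as piperidine, an amine, a carboxylic acid or a longer alkyl chain at this place would still read like compounds 1, 2 and 3. The shared core and the acylhydrazone link are also constant throughout, so these compounds say nothing about how much of the antiproliferative reading depends on either.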